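Acetyl to cyclopentylcarbonyl: an unread step

The compounds below may be only part of what the source reports. "The series", "measured", "known", "first", "only" and "open" are said of these compounds alone.

Three compounds have been run in an assay on Sf9 cells for inhibition of mitogen-activated protein kinase kinase kinase 14 (Homo sapiens), read by ADP-Glo, with a stated time of 60 min; a higher number here means a weaker inhibitor, a lower number a stronger inhibitor. Compound 1 `Cc1ccc(-c2c(N)n[nH]c2C)cc1C` reaches only the limit of the assay, > 100000 nM. Compound 2 `Cc1c(N)n[nH]c1-c1ccc(Cl)c(Cl)c1` likewise returns only a limit, > 100000 nM. Going by the values given here, compound 3 `CC(=O)n1nc(C)c(-c2ccc(Cl)c(Cl)c2)c1N` is the single member with a number, 8400 nM, so it stands alone among the values shown, the other two sitting at the limit of > 100000 nM in this assay, at which 2 of the 3 values shown sit. Among the compounds with values here, no pair of measured compounds differs in one place, so no measured step is available to calibrate the series.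

Compound 4 `Cc1nn(C(=O)C2CCCC2)c(N)c1-c1ccc(Cl)c(Cl)c1` has not yet been measured in this assay. It differs from compound 3 by cyclopentyl in place of methyl on a carbonyl carbon. Within the data shown here, nothing among the measured compounds speaks to a change of this kind. The expected step is small, a 1.4-fold lower number from compound 3 to compound 4 (0.15 log units; within the scatter), with no direction favoured beyond the scatter of the assay. Compound 4 is accordingly estimated at 6000 nM, within a range from 1500 nM to 30000 nM.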

Compound 4, half-maximal inhibitory concentration: 41000 nM
For compound 4 the middle estimate is 6.8-fold (0.83 log units) below the measured one; measured number above the stated range.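

Going by these compounds alone, the first measured step shows that the group on this carbonyl carbon, whose other neighbour is the aromatic nitrogen, affects the read-out in this assay. Cyclopentyl in place of methyl gives a 4.9-fold higher number from compound 3 to compound 4 (0.69 log units; beyond the scatter), so the ring is not a neutral swap for methyl here. Even so, compound 4 still gives a measured number, 41000 nM, and not a limit, so this position can carry cyclopentylcarbonyl and still be read.

From the compounds shown here alone, whether the rise belongs to the ring itself or would also appear with ethyl, isopropyl or phenyl on the same carbonyl carbon stays open, as does the effect of an amine there. This single step carries the whole reading of the position, and steps to the remaining compounds cannot be read, as their values are limits and not numbers: the limit of > 100000 nM in this assay, at which 2 of the 4 values shown sit.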